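The source may report more compounds than this note shows. Statements on the series, on what has been measured and on what is new or still open speak of the compounds shown alone.

- compound 1 `O=C(NO)c1cc2ccn(Cc3ccc(F)cc3)c2cn1`: 159000 nM
- compound 2 `NC(=O)c1cc(Cn2ccc3cc(C(=O)NO)ncc32)ccc1F`: > 10000 nM (a limit)

Among the measured compounds shown here, in an ADME assay on CEM-SS cells (Homo sapiens) for cytotoxicity, read by XTT assay (on this read-out lower numbers stand for higher toxicity in this test and higher numbers for lower toxicity in this test), compound 1 gives 159000 nM, the only exact number available, so there is no range of measured numbers in which to place it. For compound 2, > 10000 nM is a limit and not a number.

Compound 3 `CC(C)CN(O)C(=O)c1cc2ccn(Cc3ccc(F)cc3)c2cn1` keeps the core of compound 1 and differs only in its hydroxycarbamoyl group: isobutyl in place of hydrogen on an amide-type nitrogen, which turns hydroxycarbamoyl into hydroxy(isobutyl)carbamoyl. For the measured compounds named here, the one measured step, a step that the limit leaves unreadable from compound 1 to compound 2, is a different change made at a different place, and its size cannot be read. It therefore offers no guide to size or direction, so no shift beyond the usual scatter is expected in this assay, although the uncertainty is wide. The expected outcome is a 1.3-fold lower number from compound 1 to compound 3 (0.12 log units; within the scatter). Compound 3 is estimated at 120000 nM, with an expected range of 30000 nM to 400000 nM.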

Compound 3, half-maximal cytotoxic concentration: 102000 nM
Compound 3: the middle estimate sits 1.2-fold (0.07 log units) above what was measured, within the range that was stated.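

In this assay, isobutyl in place of hydrogen on the amide-type nitrogen gives a 1.6-fold lower number from compound 1 to compound 3 (0.19 log units; within the scatter), so this read-out does not tell the two compounds apart, even with the added isobutyl chain at this position. This is the only readable step among the compounds shown, and the step to compound 2 cannot be read, since the value for compound 2 is a limit and not a number. Nothing measured here gives a reason for this result.

A single group on this nitrogen leaves open what a methyl group, a longer chain or a chain ending in an amine would do in the same place. Also open, as far as these compounds go, is how this read-out would respond if a methoxy group took the place of the hydroxy group on that nitrogen.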